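The source may hold more compounds than are shown below. What is called first, only, known or untested is meant among the compounds shown, and "the series" means these compounds.

Measured compounds in a functional assay on SMMC-7721 cells (Homo sapiens) for cytotoxicity, read by MTT assay, with a stated time of 4 days; a higher number here means a weaker inhibitor, a lower number a stronger inhibitor:
Compound 1 `C=C1C[C@]23C[C@@]1(O)CC[C@H]2c1ccc(O)c(C)c1[C@@H]3Cn1cc(-c2ccc(OC)cc2)nn1` reports only a limit, > 20000 nM.
Compound 2 `C=C1C(=O)[C@]23C[C@@]1(O)CC[C@H]2c1ccc(O)c(C)c1[C@@H]3Cn1cc(-c2ccc(C(F)(F)F)cc2)nn1` gives 1440 nM.
Compound 3 `Cc1ccc(S(=O)(=O)Oc2ccc3c(c2C)[C@H](Cn2cc(-c4ccc(Cl)cc4)nn2)[C@@]24CC(=O)[C@@](C)(CC[C@@H]32)C4)cc1` reports only a limit, > 20000 nM.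

Within the data shown here, compound 2 holds the only actual number in this assay; the two other results are limits rather than numbers. Compound 4 `C=C1C(=O)[C@]23C[C@@]1(O)CC[C@H]2c1ccc(O)c(C)c1[C@@H]3Cn1cc(-c2ccc(OC)cc2)nn1` is obtained from compound 2 by the change (methoxy in place of trifluoromethyl on an aromatic carbon). No measured pair shows this change by itself, so its effect cannot be read from the data shown. Since two of the three results sit at the limit of > 20000 nM in this assay, at which 2 of the 3 values shown sit, compound 4 is expected to move toward weaker inhibition by a step of a 4.2-fold higher number from compound 2 to compound 4 (0.62 log units; beyond the scatter), which would probably exceed the scatter. Compound 4 is accordingly estimated at about 6000 nM, with a likely range from 1500 nM to 20000 nM.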

Compound 4, half-maximal inhibitory concentration: 860 nM
Compound 4: the middle estimate sits 7.0-fold (0.84 log units) above what was measured; the whole stated range lies above it.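

In this assay, exchanging trifluoromethyl for methoxy on the aromatic carbon para to a large group gives a 1.7-fold lower number from compound 2 to compound 4 (0.22 log units; within the scatter). This first pair differing in one place therefore shows no separable difference between the 4-(trifluoromethyl)phenyl and 4-methoxyphenyl forms, and both compounds retain measured numbers rather than limits. Nothing in the data shown accounts for this result. Going by these compounds, whether an amine, a carboxylic acid or a plain hydrogen at this position would read the same remains open. So does whether any group here would move the value beyond the scatter.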